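The source may report more compounds than this note shows. Statements on the series, on what has been measured and on what is new or still open speak of the compounds shown alone.

Measured compounds:
compound 1 `CCCc1nc(-c2ccccc2)c(CNCCN2CCN(c3cccc(C)c3)CC2)o1` — 43.1%
compound 2 `CCCc1nc(-c2ccccc2)c(CNCCCN2CCN(c3cccc(F)c3)CC2)o1` — 68.9%
compound 3 `CCCc1nc(-c2ccccc2)c(CNCCN2CCN(c3ccccc3C(F)(F)F)CC2)o1` — 54.6%

In an assay on HEK293 cells for inhibition of Voltage-dependent T-type calcium channel subunit alpha-1G (Homo sapiens), read by fluorescence, tested at 10 uM (on this read-out lower numbers stand for less inhibition and higher numbers for more inhibition at the one concentration tested (going by the name of the read-out)), compound 2 gives the highest of the three numbers. Its nearest neighbour is compound 3, whose number is lower beyond the scatter, and the furthest is compound 1, whose number is lower still, again beyond the scatter.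

Compound 4 `CCCc1nc(-c2ccccc2)c(CNCCCN2CCN(c3ccc(C(F)(F)F)cc3)CC2)o1` has not been measured yet. It differs from compound 2 in one place: 4-(trifluoromethyl)phenyl in place of 3-fluorophenyl on an amine nitrogen in a ring.

Going by the values given here, only one measured step changes the group on that ring nitrogen: a number 11.5 percentage points higher from compound 1 to compound 3 (beyond the scatter). That step brought a trifluoromethyl-bearing phenyl in place of a methyl-bearing one and raised inhibition modestly, though it was taken on the core of compound 1, which is not the same as the core of compound 2, and the trifluoromethyl sat at a different place on the phenyl. Among the compounds with values here, it gives only a loose hint that the change from compound 2 to compound 4 could raise inhibition slightly or leave it within the scatter; no measured step tests a 4-(trifluoromethyl)phenyl or removes a fluorine from the phenyl.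

Compound 4 is therefore expected to give about 72%, with a plausible range from 55% to 88%. The step this estimate implies, a number 3.1 percentage points higher from compound 2 to compound 4 (within the scatter), is expected to stay within the scatter.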

Compound 4, a percentage reported as inhibition, at one concentration (the size of the read-out at that concentration, not a potency): 51.6%
The estimate for compound 4 lay 20.4 percentage points above the measured number, and the stated range ends above it.
By their numbers in this assay, from the lowest: compounds 1, 4 and 3 (each within the scatter of the next, the first and the last beyond it); then compound 2.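

In this assay, the group on this ring nitrogen matters on the core shared by compound 2 and compound 4: the number is a number 17.3 percentage points lower from compound 2 to compound 4 (beyond the scatter) when 4-(trifluoromethyl)phenyl replaces 3-fluorophenyl, a step beyond the scatter. Going by these compounds alone, the only earlier step at this nitrogen went the other way, a number 11.5 percentage points higher from compound 1 to compound 3 (beyond the scatter), so a trifluoromethyl on the phenyl does not go with a higher number in every case, although the two steps differ in their cores, in the groups that leave and in where the trifluoromethyl sits. Nothing shown here bears on why the number fell in this new step.

This swap changes both the kind of group on the phenyl and where it sits, so the compounds shown cannot say which of the two matters, and 3-(trifluoromethyl)phenyl or 4-fluorophenyl on the same core would separate them. As far as these compounds go, it also stays open whether a plain phenyl, with neither fluorine nor trifluoromethyl, would give a number closer to that of compound 2 or to that of compound 4.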